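The source may hold more compounds than are shown below. What is called first, only, known or untested is meant among the compounds shown, and "the series" means these compounds.

Compound 1 (`CC(=O)N1CCC(C)(C(=O)N2CC[C@](c3ccc(C(OCc4c(F)cccc4F)(C(F)(F)F)C(F)(F)F)cc3)(S(=O)(=O)c3ccc(F)cc3)C2)CC1`) gives 1% in an ADME assay on microsomes from liver (Homo sapiens) for metabolic stability, with a stated time of 10 min; a higher number here means that more of the compound is left, a lower number that less of the compound is left
Compound 2 (`O=C(O)[C@H]1CC[C@H](C(=O)N2CC[C@](c3ccc(C(OCc4ccccc4OC(F)(F)F)(C(F)(F)F)C(F)(F)F)cc3)(S(=O)(=O)c3ccc(F)cc3)C2)CC1`) gives 93% in this assay

Compound 2 stands highest of the two, and its gap to compound 1 lies beyond the scatter. Compound 3 (`O=C(O)[C@H]1CC[C@H](C(=O)N2CC[C@](c3ccc(C(OCC4CCCCC4)(C(F)(F)F)C(F)(F)F)cc3)(S(=O)(=O)c3ccc(F)cc3)C2)CC1`) differs from compound 2 in one place (cyclohexyl in place of 2-(trifluoromethoxy)phenyl on a saturated chain carbon bound to an oxygen on a saturated carbon), with cyclohexyl in place of 2-(trifluoromethoxy)phenyl on a saturated chain carbon bound to an oxygen on a saturated carbon. Among the measured compounds shown here, no measured pair shows this change, so the expectation starts from compound 2 at 93% and points to a moderate fall in this assay that probably exceeds the scatter. The expected step is a number 21 percentage points lower from compound 2 to compound 3 (beyond the scatter) on this estimate. For compound 3 the estimated value is 72% with an expected range from 42% to 94% in this measurement.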

Compound 3, percent of the compound remaining: 92%
Estimate against measurement, compound 3: 20 percentage points below; the measured number falls inside the stated range.
By their numbers in this assay, from the lowest: compound 1; then compounds 3 and 2 (each within the scatter of the next).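

In this assay, the change from 2-(trifluoromethoxy)phenyl to cyclohexyl gives a number 1 percentage points lower from compound 2 to compound 3 (within the scatter). At this place, on a saturated chain carbon bound to an oxygen on a saturated carbon, the aromatic ring and the trifluoromethoxy group are therefore not needed for a reading at this level: a non-aromatic ring of carbon only, with fewer heavy atoms, serves equally well. The two groups cannot be told apart here. As far as these compounds go, whether an amine or a longer chain in place of cyclohexyl would read alike remains open. Nothing available explains why the two groups match.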